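This account rests on a few compounds, and the source may have more. Where it says the series, first, only, none or still open, it means among the compounds named here.

Working notes on the series.

Compound 1 `CCCCCc1c(C(C)C)nc(C(C)C)c(CO)c1-c1ccccc1NC(C)=O` gives 13% in an assay on CHO cells for inhibition of Glucagon receptor (Homo sapiens), tested at 20 uM; on this read-out higher numbers stand for more inhibition at the one concentration tested (going by the name of the read-out) and lower numbers for less inhibition. Compound 2 `CCCCCc1c(C(C)C)nc(C(C)C)c(CO)c1-c1ccc(OC)cc1` gives 37% in this assay. Among the measured compounds shown here, of the two numbers measured so far, compound 2 stands highest; the only neighbour, compound 1, lies lower by a gap beyond the usual scatter, so the two read as genuinely different. For the measured compounds named here, no pair of measured compounds differs in a single place, so the numbers give no isolated step to lean on.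

Compound 3 `CCCCCc1c(C(C)C)nc(C(C)C)c(CO)c1-c1ccc(CC)cc1` differs from compound 2 in one place: ethyl in place of methoxy on an aromatic carbon. Going by the values given here, nothing among the measured compounds speaks directly to this exchange, so the step from compound 2 to compound 3 is expected to be small, and the estimate a number 2 percentage points lower from compound 2 to compound 3 (within the scatter) stays inside the scatter in either direction. For compound 3 the estimated value in this assay is 35%, with a range from 15% to 55%.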

Compound 3, a percentage reported as inhibition, at one concentration (the size of the read-out at that concentration, not a potency): 42%
Beside the measured number, compound 3's estimate is 7 percentage points below it; low and high end bracket the measured number.
By their numbers in this assay, from the lowest: compound 1; then compounds 2 and 3 (each within the scatter of the next).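

In this assay, among the compounds shown here, ethyl in place of methoxy on an aromatic carbon gives a number 5 percentage points higher from compound 2 to compound 3 (within the scatter), the first step that isolates a single exchange. At this position, para to a large group, the hydrogen-bond acceptor of methoxy can be lost and the read-out stays within the scatter, so 4-methoxyphenyl and 4-ethylphenyl cannot be told apart on these numbers. No supporting evidence bears on why the two groups read alike.

Still open, on these data alone, is whether an amine, a carboxylic acid or a longer chain such as butyl at this same position would stay level with compound 2 and compound 3 or move beyond the scatter. Also open, as far as these compounds go, is how the hydroxymethyl and pentyl groups of the shared core contribute.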